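This account rests on a few compounds, and the source may have more. Where it says the series, first, only, none or still open, it means among the compounds named here.

Compound 1 `COc1cc2c(Oc3ccc(NC(=O)c4cc(-c5ccc(C(F)(F)F)cc5)ccn4)cc3F)ccnc2cc1OCCCN1CCCCC1` gives 870 nM in a functional assay on MKN-45 cells (Homo sapiens) for cytotoxicity, read by MTT assay, with a stated time of 72 h; a lower number here means a stronger inhibitor, a higher number a weaker inhibitor.
Compound 2 `COc1cc2c(Oc3ccc(NC(=O)c4cc(-c5ccccc5)ccn4)cc3F)ccnc2cc1OCCCN1CCCC1` gives 210 nM in this assay.
Compound 3 `COc1cc2c(Oc3ccc(NC(=O)c4cc(-c5ccc(C(F)(F)F)cc5)ccn4)cc3F)ccnc2cc1OCCCN1CCCC1` gives 260 nM in this assay.

All three share the same core and differ at two places. Compound 2 differs from compound 3 by hydrogen in place of trifluoromethyl on an aromatic carbon; in this assay this reads as a 1.2-fold higher number from compound 2 to compound 3 (0.09 log units; within the scatter), so the two values cannot be told apart. Among the measured compounds shown here, compound 1 differs from compound 3 by piperidin-1-yl in place of pyrrolidin-1-yl on a saturated chain carbon, three bonds along the chain from an oxygen on an aromatic ring; here the step is a 3.3-fold higher number from compound 3 to compound 1 (0.52 log units; beyond the scatter), and this is the only measured instance of that change.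

Compound 4 `COc1cc2c(Oc3ccc(NC(=O)c4cc(-c5ccccc5)ccn4)cc3F)ccnc2cc1OCCCN1CCCCC1` is not yet measured. It differs from compound 2 by piperidin-1-yl in place of pyrrolidin-1-yl on a saturated chain carbon, three bonds along the chain from an oxygen on an aromatic ring, the same change that separates compound 3 from compound 1, at the same place in the same words. For the measured compounds named here, compound 4 is therefore expected to show a step of a 3.3-fold higher number from compound 2 to compound 4 (0.52 log units; beyond the scatter) in this assay, set beside the measured 3.3-fold higher number from compound 3 to compound 1 (0.52 log units; beyond the scatter), because a 3.3-fold higher number from compound 3 to compound 1 (0.52 log units; beyond the scatter) is the one precedent for this change on this core. For compound 4 the estimate in this assay is 700 nM, expected to fall between 350 nM and 1400 nM.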

Compound 4, half-maximal inhibitory concentration: 270 nM
Compound 4: the middle estimate sits 2.6-fold (0.41 log units) above what was measured; the whole stated range lies above it.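

In this assay, piperidin-1-yl in place of pyrrolidin-1-yl now gives a 1.3-fold higher number from compound 2 to compound 4 (0.11 log units; within the scatter), while hydrogen in place of trifluoromethyl gives a 3.2-fold lower number from compound 1 to compound 4 (0.51 log units; beyond the scatter). Set beside its one precedent, the ring change shows two steps that cannot be told apart, even though only one of them lies beyond the scatter: the same change on two cores in this assay, a 3.3-fold higher number (0.52 log units; beyond the scatter) from compound 3 to compound 1 and a 1.3-fold higher number (0.11 log units; within the scatter) from compound 2 to compound 4, 2.6-fold (0.42 log units) apart, within the scatter of two such steps. The trifluoromethyl change reads the same way, so these four compounds do not show that either change depends on what stands at the other place, and with only two instances of each they do not show that either carries over at a fixed size: the same change on two cores in this assay, a 1.2-fold higher number (0.09 log units; within the scatter) from compound 2 to compound 3 and a 3.2-fold higher number (0.51 log units; beyond the scatter) from compound 4 to compound 1, 2.6-fold (0.42 log units) apart, within the scatter of two such steps.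

The compounds shown leave open how a morpholin-4-yl or dimethylamino group would read at the end of the 3-(pyrrolidin-1-yl)propyl chain, and whether a shorter or longer chain would alter the picture. They also leave open whether a chloro or methoxy group in the place of trifluoromethyl would behave as trifluoromethyl does on these cores.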